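Shifting a Methoxy Group: What the Binding Assay May Show

A few compounds are considered here, and "the series" means these few. Any claim that something is new, unique, unknown or untested is made for them only; others in the source may bear on it.

Compound 1 `COc1ccc(C(=O)NCc2ccc(CNS(=O)(=O)c3ccc(C)cc3)cc2)cc1` was tested in a binding assay on MDA-MB-231 cells for binding affinity to C-X-C chemokine receptor type 4 (Homo sapiens), read by immunofluorescence and microscopy, with stated times of 10 min and 30 min (a lower number here means that less compound is needed, a higher number that more compound is needed for the effect), where compound 1 gives 100 nM. Among the three measured compounds, this is the highest number. Compound 2 `Cc1ccc(S(=O)(=O)NCc2ccc(CNC(=O)c3ccc([N+](=O)[O-])cc3)cc2)cc1` gives 10 nM in this assay, and compound 3 `O=C(NCc1ccc(CNS(=O)(=O)c2ccccc2)cc1)c1cccnc1` gives 10 nM. For the measured compounds named here, the only single-point step among them, a 10-fold lower number from compound 1 to compound 2 (1.00 log units; beyond the scatter), exchanges one group for another on an aromatic carbon and lowers the number beyond the scatter. Going by the values given here, compound 3 shares no single-point step with compound 1; its value simply stands below that of compound 1.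

Compound 4 `COc1cccc(C(=O)NCc2ccc(CNS(=O)(=O)c3ccc(C)cc3)cc2)c1` keeps every atom of compound 1 but joins them differently: 3-methoxyphenyl in place of 4-methoxyphenyl on a carbonyl carbon. The methoxy group is neither removed nor exchanged, only attached at a different point of the same ring. Among the compounds with values here, no measured step bears on such a move; the step from compound 1 to compound 2 swaps the group itself for a nitro group and so offers no guide. With nothing to point either way, the expectation is no change beyond the scatter, and compound 4 is estimated at 100 nM, between 30 nM and 300 nM. That expected step is no change at the digits printed from compound 1 to compound 4 (within the scatter).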

Compound 4, effective concentration (reported as EC, without a stated level of effect): 10 nM
Estimate against measurement, compound 4: 10-fold (1.00 log units) above, outside the stated range (below it).
By their numbers in this assay, from the lowest: compounds 2, 3 and 4 (each within the scatter of the next); then compound 1.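

Where the methoxy group is attached to this ring matters in its own right: 3-methoxyphenyl in place of 4-methoxyphenyl on the carbonyl carbon gives a 10-fold lower number from compound 1 to compound 4 (1.00 log units; beyond the scatter) in this assay even though no atom is added or removed. The earlier step at this place exchanged the group itself, so it could not show that a change in how the same atoms are joined is enough to move the number, and 3-methoxyphenyl in place of 4-nitrophenyl now gives no change at the digits printed from compound 2 to compound 4 (within the scatter) even though the two groups differ. No measurement here explains why the attachment point counts for so much.

The compounds shown leave open whether the same shift on the ring would lower the number for a group other than methoxy, such as the nitro group of compound 2. They also leave open what an amine or a carboxylic acid on this ring, or a longer chain in place of the methoxy group, would do in this setting.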